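The compounds below may be only part of what the source reports. "The series", "measured", "known", "first", "only" and "open" are said of these compounds alone.

Compound 1 `CCSc1nnc(-c2cc(OC)c(OC)c(OC)c2)n1-c1ccc(OC)cc1` is measured in a functional assay on PC-3 cells (Homo sapiens) for inhibition, read by MTT assay, with a stated time of 48 h (a lower number here means a stronger inhibitor, a higher number a weaker inhibitor), at 57700 nM, the highest of the three numbers shown, though all three lie within the usual scatter of one another. Compound 2 `COc1ccc(-n2c(SCc3ccccc3)nnc2-c2cc(OC)c(OC)c(OC)c2)cc1` gives 34100 nM in this assay, and compound 3 `COc1ccc(-n2c(SCc3ccc(C)cc3)nnc2-c2cc(OC)c(OC)c(OC)c2)cc1` gives 56500 nM. Compound 4 `COc1ccc(-n2c(SCC(=O)c3ccc4ccccc4c3)nnc2-c2cc(OC)c(OC)c(OC)c2)cc1` is not yet measured; it differs from compound 1 in one place: (naphthalen-2-yl)carbonyl in place of methyl on a saturated chain carbon bound to a sulfur. For the measured compounds named here, two measured steps bear on this change, since both also replace the same methyl on that saturated chain carbon with an aromatic group: a 1.7-fold lower number from compound 1 to compound 2 (0.23 log units; within the scatter) and a 1.0-fold lower number from compound 1 to compound 3 (0.01 log units; within the scatter). Neither reaches beyond the scatter, so exchanging that methyl for an aromatic group has so far left this assay essentially unchanged. Going by the values given here, the (naphthalen-2-yl)carbonyl that enters in compound 4 is larger again and brings a carbonyl and a second ring, for which no measured step exists, so the expectation stays close to compound 1 with a wide range, a 1.4-fold lower number from compound 1 to compound 4 (0.14 log units; within the scatter). Compound 4 is estimated at 42000 nM, with a range from 15000 nM to 110000 nM.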

Compound 4, half-maximal inhibitory concentration: > 60000 nM
Compound 4: a limit, no number (the forecaster's own chance of this, stated with the estimate: 15%); middle value at least 1.4-fold (0.15 log units) away from the limit.
By their numbers in this assay, from the lowest: compounds 2, 3 and 1 (each within the scatter of the next). At a limit, above all of these: compound 4.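

In this assay compound 4 gives no number, only a limit of the assay: the limit of > 60000 nM in this assay, at which 1 of the 4 values shown sits. Its steps are therefore floors: an at least 1.0-fold higher number from compound 1 to compound 4 (0.01 log units; that floor lies within the scatter), an at least 1.0-fold higher number from compound 3 to compound 4 (0.02 log units; that floor lies within the scatter) and an at least 1.7-fold higher number from compound 2 to compound 4 (0.24 log units; that floor lies within the scatter). So the (naphthalen-2-yl)carbonyl, the largest group yet on this saturated chain carbon bound to a sulfur, brings no lower number, though each floor lies within the scatter and how far compound 4 truly sits from the others cannot be read.

The compounds shown leave open whether the carbonyl or the second ring matters here, which a benzoyl group or a naphthalen-2-ylmethyl group would help to separate. Also open, as far as these compounds go, is whether an amine or a carboxylic acid at this place would bring the number clearly down.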